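Indolyl in Place of Methoxyphenyl at a Limit

The compounds below may be only part of what the source reports. "The series", "measured", "known", "first", "only" and "open" are said of these compounds alone.

compound 1 `COc1cccc(-c2nc3cccc(-c4cc(OC)c(OC)c(OC)c4)c3o2)c1`: > 25000 nM
compound 2 `COc1cc(-c2cccc3nc(-c4ccc(F)cc4)oc23)cc(OC)c1OC`: > 25000 nM
compound 3 `COc1cc(-c2nc3cccc(-c4cc(OC)c(OC)c(OC)c4)c3o2)ccc1O`: 10300 nM

In a functional assay on U-251 cells (Homo sapiens) for antiproliferative activity, read by MTT assay, with a stated time of 48 h (on this read-out higher numbers stand for weaker inhibition and lower numbers for stronger inhibition), compound 1 stands at a limit of the assay, > 25000 nM. Compound 2 likewise stands at a limit, > 25000 nM, as noted in the limit of > 25000 nM in this assay, at which 2 of the 3 values shown sit. Compound 3 alone gives a number, 10300 nM. The step of an at least 2.4-fold lower number from compound 1 to compound 3 (0.38 log units; beyond the scatter) is readable, whereas a step that the two limits leave unreadable from compound 1 to compound 2 cannot be read. Compound 4 `COc1cc(-c2cccc3nc(-c4ccc5cc[nH]c5c4)oc23)cc(OC)c1OC` differs from compound 1 by 1H-indol-6-yl in place of 3-methoxyphenyl on an aromatic carbon. Going by the values given here, only one measured step leads away from compound 1 to a number, an at least 2.4-fold lower number from compound 1 to compound 3 (0.38 log units; beyond the scatter), and it is at least modest. Compound 4 is therefore expected to give a modest step, an at least 2.0-fold lower number from compound 1 to compound 4 (0.31 log units; beyond the scatter). Compound 4 is estimated at 12000 nM, within 4000 nM to 30000 nM.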

Compound 4, half-maximal inhibitory concentration: 300 nM
Estimate against measurement, compound 4: 40-fold (1.60 log units) above, and the stated range ends above it.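

Going by these compounds alone, at this position, next to the ring nitrogen and next to the ring oxygen, 1H-indol-6-yl gives the first large step in this assay: a 34-fold lower number from compound 3 to compound 4 (1.54 log units; beyond the scatter). The steps from the two other aryl groups are also large: an at least 83-fold lower number from compound 1 to compound 4 (1.92 log units; beyond the scatter) and an at least 83-fold lower number from compound 2 to compound 4 (1.92 log units; beyond the scatter). These two sizes are only lower bounds, since compound 1 and compound 2 stand at a limit: the limit of > 25000 nM in this assay, at which 2 of the 4 values shown sit.

A benzofuran-6-yl group, with a ring oxygen in place of the indole nitrogen, and a 4-aminophenyl group could separate the hydrogen-bond donor from the fused ring. From the compounds shown here alone, what either would give at this position stays open.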